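The source may report more compounds than this note shows. Statements on the series, on what has been measured and on what is new or still open speak of the compounds shown alone.

Compound 1 `Cc1ccc(C(=O)N2N=C(c3ccc(N4CCN(C)CC4)cc3)CC2c2ccc(N(C)C)cc2)cc1` gives -0.7% in a functional assay on MDA-MB-231 cells (Homo sapiens) for inhibition, read by sulforhodamine B assay, tested at 10 uM; a lower number here means less inhibition, a higher number more inhibition at the concentration tested (going by the name of the read-out); compound 2 `CN1CCN(c2ccc(C3=NN(C(=O)c4ccc(F)cc4)C(c4ccc(N(C)C)cc4)C3)cc2)CC1` gives 3.5%; compound 3 `CN1CCN(c2ccc(C3=NN(C(=O)c4ccc(C(F)(F)F)cc4)C(c4ccc(N(C)C)cc4)C3)cc2)CC1` gives 55.4%.

The steps of a number 56.1 percentage points higher from compound 1 to compound 3 (beyond the scatter) and a number 51.9 percentage points higher from compound 2 to compound 3 (beyond the scatter) set compound 3 highest of the three, while the remaining step, a number 4.2 percentage points higher from compound 1 to compound 2 (within the scatter), stays within the scatter. Compound 4 `CN(C)c1ccc(C2CC(c3ccc(-n4ccnc4)cc3)=NN2C(=O)c2ccc(C(F)(F)F)cc2)cc1` differs from compound 3 in one place: 1H-imidazol-1-yl in place of 4-methylpiperazin-1-yl on an aromatic carbon. For the measured compounds named here, none of the measured steps touches this group; all three change the substituent on the benzoyl ring while the 4-methylpiperazin-1-yl stays in place. Compound 4 keeps the trifluoromethyl that accompanies the high number of compound 3. Going by the values given here, with no bearing step, the direction of the change cannot be read from these data, and the estimate is a moderate drop, a number 17.4 percentage points lower from compound 3 to compound 4 (beyond the scatter), carrying a wide range. Compound 4 is expected to give 38%, between 8% and 65%.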

Compound 4, a percentage reported as inhibition, at one concentration (the size of the read-out at that concentration, not a potency): 17.9%
Beside the measured number, compound 4's estimate is 20.1 percentage points above it, within the range that was stated.
By their numbers in this assay, from the lowest: compounds 1 and 2 (each within the scatter of the next); then compound 4; then compound 3.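

Exchanging 4-methylpiperazin-1-yl for 1H-imidazol-1-yl, with the trifluoromethyl kept, gives a number 37.5 percentage points lower from compound 3 to compound 4 (beyond the scatter) in this assay. For the compounds shown here, this shows that the position on the aromatic carbon, which no earlier step touched, also moves the number, and that the trifluoromethyl does not settle the reading alone. Nothing measured here explains the drop. On these data alone, it remains open whether a morpholin-4-yl or a dimethylamino group at this position would keep the number closer to that of compound 3. As far as these compounds go, it also remains open how 1H-imidazol-1-yl behaves with fluoro or methyl in place of the trifluoromethyl.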